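Varying the aryl group on a double-bonded carbon: compound 4

The compounds below may be only part of what the source reports. "The series", "measured", "known", "first", "only" and "open" are said of these compounds alone.

Measured compounds:
- compound 1, `COc1ccccc1/C=c1/[nH]c(=O)/c(=C\c2ccccc2OC)n(C)c1=O`, 16900 nM
- compound 2, `C=CCn1c(=O)/c(=C\c2cccc(F)c2)[nH]c(=O)/c1=C\c1ccccc1OC`, 25600 nM
- compound 3, `C=CCn1c(=O)/c(=C\c2cccc(Cl)c2Cl)[nH]c(=O)/c1=C\c1ccccc1OC`, 4500 nM

All three were tested in a functional assay on NCI-H1975 cells (Homo sapiens) for cytotoxicity, read by CCK-8 assay, with a stated time of 72 h; on this read-out higher numbers stand for weaker inhibition and lower numbers for stronger inhibition. Among them compound 3 gives the lowest number, with 4500 nM; compound 1 sits higher, at 16900 nM, and compound 2 higher still, at 25600 nM. Compound 4, `C=CCn1c(=O)/c(=C\c2ccccc2C(F)(F)F)[nH]c(=O)/c1=C\c1ccccc1OC`, has not yet been measured. It differs from compound 3 in one place: 2-(trifluoromethyl)phenyl in place of 2,3-dichlorophenyl on a double-bonded chain carbon bound to an aromatic carbon.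

Within the data shown here, only one measured step concerns the same position, a 5.7-fold lower number from compound 2 to compound 3 (0.76 log units; beyond the scatter), and it swaps in the very group that now leaves, so it does not tell directly how the trifluoromethyl-bearing ring will behave. Compound 1, which carries a different group at that position, gives a higher number than compound 3. Among the measured compounds shown here, with no step on this exact exchange, the expectation is loose: compound 4 is estimated to give a somewhat higher number than compound 3, a 2.0-fold higher number from compound 3 to compound 4 (0.30 log units; within the scatter), with wide uncertainty. The estimate for compound 4 in this assay is 9000 nM, within a range of 2500 nM to 30000 nM.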

Compound 4, half-maximal inhibitory concentration: 14500 nM
Compound 4: middle estimate off by 1.6-fold (0.21 log units), on the low side, and the stated range covers the measured number.
By their numbers in this assay, from the lowest: compound 3; then compounds 4, 1 and 2 (each within the scatter of the next).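

In this assay, replacing 2,3-dichlorophenyl with 2-(trifluoromethyl)phenyl on this carbon gives a 3.2-fold higher number from compound 3 to compound 4 (0.51 log units; beyond the scatter), so the low number of compound 3 does not carry over to every substituted phenyl ring placed here. The 2-(trifluoromethyl)phenyl and 3-fluorophenyl rings cannot be told apart, with a 1.8-fold lower number from compound 2 to compound 4 (0.25 log units; within the scatter) separating them, and among these three rings only 2,3-dichlorophenyl stands apart, with a lower number than both. No supporting data explain why these rings differ in this way.

From the compounds shown here alone, it remains open whether one chlorine, as in 2-chlorophenyl or 3-chlorophenyl, would be enough to keep a number as low as that of compound 3. Going by these compounds, how a phenyl ring bearing a nitrile or an amine would behave on this carbon also remains unknown.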